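Methyl in Place of Methoxy on a Shared Core

The compounds below may be only part of what the source reports. "The series", "measured", "known", "first", "only" and "open" are said of these compounds alone.

Of the compounds shown here, three built on one shared core have so far been measured in an assay on isolated protein for inhibition of Amine oxidase [flavin-containing] A (Homo sapiens), read by fluorescence and Amplex Red, with stated times of 15 min and 20 min, tested at 100 uM; a higher number here means more inhibition at the concentration tested (going by the name of the read-out), a lower number less inhibition. Compound 1 `O=C(NC1CCN(Cc2ccccc2)CC1)c1coc2ccccc2c1=O` gives 63.8%. Compound 2 `O=C(NCCC1CCN(Cc2ccccc2)CC1)c1coc2ccccc2c1=O` gives 68.6%. Compound 3 `COc1ccc2occ(C(=O)NCCC3CCN(Cc4ccccc4)CC3)c(=O)c2c1` gives 72.4%. Compound 3 therefore shows the highest of the three numbers, but its gaps to compound 2 and to compound 1 both lie within the scatter, so the three compounds cannot be ranked against one another. For the measured compounds named here, the single one-place step among them is a number 3.8 percentage points higher from compound 2 to compound 3 (within the scatter), and it too stayed within the scatter.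

Compound 4 `Cc1ccc2occ(C(=O)NCCC3CCN(Cc4ccccc4)CC3)c(=O)c2c1` has not yet been measured in this assay. It differs from compound 3 in one place: methyl in place of methoxy on an aromatic carbon. Going by the values given here, the only measured step that bears on this change is a number 3.8 percentage points higher from compound 2 to compound 3 (within the scatter), which also altered an aromatic carbon of the shared core and produced nothing beyond the scatter. Among the compounds with values here, with that as the sole guide, the expected step is a number 2.4 percentage points lower from compound 3 to compound 4 (within the scatter), that is, no movement beyond the scatter in either direction. Compound 4 is accordingly estimated at 70%, with a likely range from 58% to 82%.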

Compound 4, a percentage reported as inhibition, at one concentration (the size of the read-out at that concentration, not a potency): 30.6%
Compound 4: the middle estimate sits 39.4 percentage points above what was measured; the measured number lies below the stated range.
By their numbers in this assay, from the lowest: compound 4; then compounds 1, 2 and 3 (each within the scatter of the next).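

In this assay, this aromatic carbon of the shared core proves far from indifferent to what it carries: methyl in place of methoxy gives a number 41.8 percentage points lower from compound 3 to compound 4 (beyond the scatter), and methyl in place of hydrogen gives a number 38 percentage points lower from compound 2 to compound 4 (beyond the scatter). Set beside a number 3.8 percentage points higher from compound 2 to compound 3 (within the scatter), these steps show a pattern that the earlier compounds could not: hydrogen and methoxy cannot be told apart here, while methyl stands well below both, so the number does not simply track how many heavy atoms the group holds, at least across compounds 2, 3 and 4. Nothing available explains why methyl behaves so differently from the other two at this position.

As far as these compounds go, it remains open whether this low number is peculiar to methyl or would also appear with other groups on the same carbon, such as a chlorine atom, an ethyl group or a hydroxyl group. From the compounds shown here alone, it is equally open whether methyl on the same aromatic carbon of compound 1, with its different link between the amide and the nitrogen-containing ring, would bring a drop of similar size.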